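The compounds below may be only part of what the source reports. "The series", "measured", "known", "first", "only" and "open" are said of these compounds alone.

In an ADME assay on HepG2 cells (Homo sapiens) for cytotoxicity, read by CellTiter-Glo, with a stated time of 48 h (a higher number here means that more compound is tolerated, a lower number that less compound is tolerated), compound 1 (`CS(=O)(=O)c1ccc(-c2nc3ccc(Br)cc3nc2-c2ccc(Cl)cc2)cc1`) gives 2000 nM. Compound 2 (`CCCCNc1nc2ccccc2nc1S(C)(=O)=O`) gives 12600 nM. Compound 3 (`CCCCNc1nc2cc(OC)ccc2nc1S(C)(=O)=O`) gives > 100000 nM, which is a limit of the assay and not a number. Compound 3 therefore has no exact position among the values.

Compound 4 (`COc1ccc2nc(S(C)(=O)=O)c(NC3CCCCC3)nc2c1`) puts cyclohexyl in place of butyl on a nitrogen on an aromatic ring.

Among the measured compounds shown here, the only measured step is an at least 7.9-fold higher number from compound 2 to compound 3 (0.89 log units; beyond the scatter), with methoxy in place of hydrogen on an aromatic carbon. For the measured compounds named here, it bears on the new change only indirectly, since it leaves the butyl group untouched and no measured step alters the group on that nitrogen. The size of the next step is therefore uncertain. Compound 2 at 12600 nM shows that a butylamino compound can give a real number, so a lower number is expected, though perhaps only a modest drop. The expected change is an at least 1.6-fold lower number from compound 3 to compound 4 (0.22 log units; that floor lies within the scatter), and another limit reading would be no surprise. For compound 4 the estimated value is 60000 nM, with an expected range from 20000 nM to 100000 nM.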

Compound 4, half-maximal cytotoxic concentration: 79400 nM
Compound 4: the middle estimate sits 1.3-fold (0.12 log units) below what was measured; the measured number falls inside the stated range.
By their numbers in this assay, from the lowest: compound 1; then compound 2; then compound 4. At a limit, above all of these: compound 3.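

Among the compounds shown here, compound 4 is the first compound here to change the group on this nitrogen, and putting cyclohexyl in place of butyl gives an at least 1.2-fold lower number from compound 3 to compound 4 (0.10 log units; that floor lies within the scatter). The true size of this step in this assay cannot be read because compound 3 stands at a limit and not at a number: the limit of > 100000 nM in this assay, at which 1 of the 4 values shown sits. What is new is that a compound keeping the methoxy group now has an exact place among the values, although this floor alone does not show that the change from butylamino to cyclohexylamino moves the number at all.

Going by these compounds, it remains open whether cyclohexyl would give a similar step on a compound without the methoxy group. Also open, on these data alone, is how a longer chain, a benzyl group or a chain ending in an amine would read on this nitrogen.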